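The compounds below may be only part of what the source reports. "The series", "measured", "known", "first", "only" and "open" are said of these compounds alone.

Measured so far in a functional assay on HepG2 cells (Homo sapiens) for cytotoxicity; a lower number here means that less compound is tolerated, a higher number that more compound is tolerated:
Compound 1 `CCCC(=O)Nc1nc(N)nc2c1ncn2[C@H]1CO[C@@H](CO)O1`: > 100000 nM (a limit)
Compound 2 `CCCCCC(=O)Nc1nc(N)nc2c1ncn2[C@H]1CO[C@@H](CO)O1`: > 100000 nM (a limit)

Compound 2 stands at > 100000 nM, which is a limit and not a number. Among the measured compounds shown here, the series so far shows (the limit of > 100000 nM in this assay, at which 2 of the 2 values shown sit).

Compound 3 `CCCCCCCC(=O)Nc1nc(N)nc2c1ncn2[C@H]1CO[C@@H](CO)O1` differs from compound 2 by ethyl in place of hydrogen on a saturated chain carbon, five bonds along the chain from a carbonyl carbon. For the measured compounds named here, the one measured step that bears on this is a step that the two limits leave unreadable from compound 1 to compound 2, also ethyl in place of hydrogen, there three bonds along the chain from a carbonyl carbon. It gives no size to carry over, so no step beyond the scatter is expected in this assay, and no direction can be assigned. The expected step is a number no higher from compound 2 to compound 3 (the limit leaves the size open). For compound 3 the estimate is 100000 nM, with an expected range from 50000 nM to 200000 nM.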

Compound 3, half-maximal cytotoxic concentration: > 100000 nM
Compound 3: a limit, no number; the forecaster's own chance of this, stated with the estimate: 80%; the middle value sits exactly at the limit.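

In this assay, among the compounds shown here, compound 1, compound 2 and compound 3 all stand at a limit of the assay, not at a number, so no step among them can be read. From the compounds shown here alone, whether these chains differ at all in this assay stays open, as does the concentration at which any of the three becomes cytotoxic.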